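Pyridin-3-yl for phenyl on the shared core

The source may hold more compounds than are shown below. What is called first, only, known or untested is meant among the compounds shown, and "the series" means these compounds.

Compound 1 `O=C(/C=C/c1ccccc1)N1CCc2c(Cl)c(O)c(O)c(Cl)c2C1` gives 83% in a functional assay (Homo sapiens), tested at 1 uM; a lower number here means a stronger effect, a higher number a weaker effect of the compound at the concentration tested. Compound 2 `N#Cc1ccc(CCCC(=O)N2CCc3c(Cl)c(O)c(O)c(Cl)c3C2)nc1` gives 86% in this assay, and the two numbers lie within the scatter of one another, so compound 1 stands together with compound 2 rather than apart from it. Compound 3 `O=C(/C=C/c1cccnc1)N1CCc2c(Cl)c(O)c(O)c(Cl)c2C1` has not been measured. It differs from compound 1 in one place: pyridin-3-yl in place of phenyl on a double-bonded chain carbon bound to a double-bonded chain carbon. Among the compounds with values here, no measured pair shows this change, so its size is unknown. The step expected in this assay is a number 2 percentage points higher from compound 1 to compound 3 (within the scatter), none beyond the scatter. Compound 3 is estimated at 85%, between 70% and 98%.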

Compound 3, a percentage reported as activity, at one concentration (the size of the read-out at that concentration, not a potency): 100%
Compound 3: the middle estimate sits 15 percentage points below what was measured, outside the stated range (above it).
By their numbers in this assay, from the lowest: compounds 1 and 2 (each within the scatter of the next); then compound 3.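

On the double-bonded chain carbon of the shared core, a single ring atom matters: in this assay, pyridin-3-yl in place of phenyl gives a number 17 percentage points higher from compound 1 to compound 3 (beyond the scatter) and so a weaker effect at the concentration tested. Within the data shown here, this is the first step that can be read, as compound 1 and compound 2 differ in more than one place. No measured evidence bears on the reason for this step.

From the compounds shown here alone, whether a thiophene ring or a fluorophenyl group at this place would keep the effect of compound 1 stays open. So does whether the same exchange would give a similar step on a longer chain.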